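The source may hold more compounds than are shown below. What is called first, only, known or untested is meant among the compounds shown, and "the series" means these compounds.

Of the compounds shown here, three have so far been measured in a functional assay on KB cells (Homo sapiens) for cytotoxicity, read by MTT assay, with a stated time of 72 h; a lower number here means that less compound is needed, a higher number that more compound is needed for the effect. Compound 1 `COc1ccc(Nc2cc(C3CCCCC3)oc(=O)c2)cc1` gives 8.32 uM. Compound 2 `O=c1cc(Nc2ccccc2)cc(-c2ccccc2)o1` gives 0.13 uM, and compound 3 `O=c1cc(NC2CCCCC2)cc(-c2ccccc2)o1` gives 16 uM. Among these three numbers compound 1 stands second highest: its value and that of compound 3 lie within the usual scatter of each other, while compound 2 sits far lower. Among the measured compounds shown here, the one single-point step seen so far, a 120-fold higher number from compound 2 to compound 3 (2.09 log units; beyond the scatter), concerns the group on the nitrogen, not the ring carbon.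

Compound 4 `CCCCCc1cc(Nc2ccc(OC)cc2)cc(=O)o1` differs from compound 1 in one place: pentyl in place of cyclohexyl on an aromatic carbon. For the measured compounds named here, no measured step touches this position, so the only guide is the shared core and the nearby values of compound 1 and compound 3. Both groups are carbon chains or rings of similar size, so a step within the scatter is expected, with a 1.0-fold lower number from compound 1 to compound 4 (0.02 log units; within the scatter). Compound 4 is therefore estimated at 8 uM in this assay, within a range from 3 uM to 25 uM.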

Compound 4, concentration for half-maximal effect: 10.1 uM
Estimate against measurement, compound 4: 1.3-fold (0.10 log units) below; low and high end bracket the measured number.
By their numbers in this assay, from the lowest: compound 2; then compounds 1, 4 and 3 (each within the scatter of the next).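

In this assay, the first step measured at this position is a 1.2-fold higher number from compound 1 to compound 4 (0.08 log units; within the scatter), so the cyclohexyl and pentyl groups on this aromatic carbon next to the ring oxygen cannot be told apart. Here, then, a closed ring of carbon and an open chain give numbers within the usual scatter, even though the step on the nitrogen between two other compounds was large. Nothing available explains why these two groups give such similar results.

Among the compounds shown here, this rests on one pair of compounds, so it remains open whether the same holds when the nitrogen carries a group other than the one in compound 1 and compound 4. As far as these compounds go, it is also open whether a methyl group, a longer chain, an amine or a carboxylic acid at this position would fit the same picture.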